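This account rests on a few compounds, and the source may have more. Where it says the series, first, only, none or still open, it means among the compounds named here.

Measured so far:
Compound 1 `COc1ccc(/C=C/C2CC(=O)C=CO2)cc1` in a functional assay on OVCAR-3 cells (Homo sapiens) for inhibition, read by sulforhodamine B assay, with a stated time of 48 h (a lower number here means a stronger inhibitor of growth, a higher number a weaker inhibitor of growth), gives 87.4 uM.
Compound 2 `COc1ccc(/C=C/C2CC(=O)C=CO2)cc1OC` in this assay gives 74.3 uM.
Compound 3 `COc1cc(/C=C/C2CC=CC(=O)O2)cc(OC)c1` in this assay gives 19.1 uM.

Compound 1 and compound 2 differ in one place, (methoxy in place of hydrogen on an aromatic carbon), and the step in this assay is a 1.2-fold lower number from compound 1 to compound 2 (0.07 log units; within the scatter). Compound 3 stands lowest of the three numbers, beyond the scatter from both compound 1 and compound 2; how the core of compound 3 differs from the core of compound 1 is not broken down here.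

Compound 4 `COc1cc(/C=C/C2CC=CC(=O)O2)cc(OC)c1OC` is not yet measured. It differs from compound 3 by methoxy in place of hydrogen on an aromatic carbon. Among the measured compounds shown here, this is the same kind of change as the one from compound 1 to compound 2, but the surroundings are not the same: in compound 4 the entering methoxy sits ortho to two methoxy groups and para to a group of 9 heavy atoms, whereas in compound 2 it sits ortho to a methoxy group and meta to a group of 9 heavy atoms. Resting on the one measured instance, the step from compound 3 to compound 4 in this assay is expected to be small, a 1.2-fold lower number from compound 3 to compound 4 (0.08 log units; within the scatter), set beside a 1.2-fold lower number from compound 1 to compound 2 (0.07 log units; within the scatter). Compound 4 is therefore estimated at 16 uM, with a range from 7 uM to 38 uM.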

Compound 4, concentration for growth inhibition (reported as GI): 44.9 uM
Estimate against measurement, compound 4: 2.8-fold (0.45 log units) below, outside the stated range (above it).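

In this assay, methoxy in place of hydrogen on an aromatic carbon does not carry over from one core to the other as a fixed step: the same change on two cores in this assay, a 1.2-fold lower number (0.07 log units; within the scatter) from compound 1 to compound 2 and a 2.4-fold higher number (0.37 log units; beyond the scatter) from compound 3 to compound 4, 2.8-fold (0.44 log units) apart, beyond the scatter of two such steps. The new result, a 2.4-fold higher number from compound 3 to compound 4 (0.37 log units; beyond the scatter), is a modest loss of growth inhibition, with the methoxy entering ortho to two methoxy groups and para to a group of 9 heavy atoms, while the earlier pair stays within the scatter. Among the compounds shown here, with only two pairs, which differ both in core and in the surroundings of the entering methoxy, the data do not show which of these separates the steps, and they give no rule for any other core.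

Open, on these data alone, is how the change behaves when the surroundings of the methoxy match on the two cores. Also open, as far as these compounds go, is whether a hydroxy group, an amine or a longer alkoxy chain at the carbon that takes the methoxy in compound 4 would follow the same direction.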